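Working notes: ethoxy added to compound 3

A few compounds are considered here, and "the series" means these few. Any claim that something is new, unique, unknown or untested is made for them only; others in the source may bear on it.

Of the compounds shown here, three have been read in a functional assay on A549 cells (Homo sapiens) for antiproliferative activity, read by sulforhodamine B assay, with a stated time of 72 h; a lower number here means a stronger inhibitor, a higher number a weaker inhibitor. Compound 1 (`COc1c(O)cc2occ(-c3csc4ccccc34)c(=O)c2c1O`) gives > 10000 nM, which is a limit of the assay and not a number. Compound 2 (`O=c1c(-c2csc3ccccc23)coc2ccccc12`) gives > 10000 nM, also a limit. Within the data shown here, compound 3 (`O=C(/C=C/c1csc2ccccc12)c1ccccc1O`) gives 5300 nM, the only actual number in the set. The rest of the set consists of the limit of > 10000 nM in this assay, at which 2 of the 3 values shown sit.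

Compound 4 (`CCOc1ccc(O)c(C(=O)/C=C/c2csc3ccccc23)c1`) has not yet been measured. It differs from compound 3 in one place: ethoxy in place of hydrogen on an aromatic carbon. This is ethoxy in place of hydrogen on an aromatic carbon, meta to a large group and para to a hydroxy group.

Among the measured compounds shown here, no measured pair in the set shows this change, so the data give no direct guide to its size in this assay. No step beyond the scatter is expected, in either direction, and the wide range reflects that single anchor. The expected change is a 1.2-fold lower number from compound 3 to compound 4 (0.07 log units; within the scatter). For compound 4 the estimated value is 4500 nM, with an expected range of 1800 nM to 10000 nM.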

Compound 4, half-maximal inhibitory concentration: 5400 nM
Compound 4: middle estimate off by 1.2-fold (0.08 log units), on the low side, within the range that was stated.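

In this assay, ethoxy in place of hydrogen on an aromatic carbon, meta to a large group and para to a hydroxy group, gives a 1.0-fold higher number from compound 3 to compound 4 (0.01 log units; within the scatter). Among these compounds, this is the first measured step, and it shows that this carbon can carry the 3 heavy atoms of ethoxy with no change beyond the scatter. Compound 3 and compound 4 remain the only pair with actual numbers, while compound 1 and compound 2 each stay at a limit of the assay: the limit of > 10000 nM in this assay, at which 2 of the 4 values shown sit.

A single substituent at one position cannot show whether this carbon is insensitive to substitution in general, and an amine, a carboxylic acid or a longer chain there could behave differently. On these data alone, whether ethoxy on another carbon of this ring would give the same result also remains open.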